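Amide aryl swaps: from compound 3 to compound 4

A few compounds are considered here, and "the series" means these few. Any claim that something is new, unique, unknown or untested is made for them only; others in the source may bear on it.

In a functional assay on MCF7 cells (Homo sapiens) for antiproliferative activity, read by sulforhodamine B assay, with a stated time of 72 h (a higher number here means a weaker inhibitor, a lower number a stronger inhibitor), compound 1 (`COc1ccc(NC(=O)Cn2nc(-c3ccccc3)c3ccccc3c2=O)cc1`) gives 77000 nM and compound 2 (`O=C(Cn1nc(-c2ccccc2)c2ccccc2c1=O)Nc1cccc(Cl)c1`) gives 74000 nM while compound 3 (`O=C(Cn1nc(-c2ccccc2)c2ccccc2c1=O)Nc1ccc(Cl)cc1`) gives 33000 nM as the lowest of the three numbers. Its lead over the other two is modest: the step of a 2.2-fold lower number from compound 2 to compound 3 (0.35 log units; beyond the scatter) and the step of a 2.3-fold lower number from compound 1 to compound 3 (0.37 log units; beyond the scatter) are both beyond the scatter but small, whereas the step of a 1.0-fold lower number from compound 1 to compound 2 (0.02 log units; within the scatter) stays within it.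

The next change leads to compound 4 (`O=C(Cn1nc(-c2ccccc2)c2ccccc2c1=O)Nc1cccc(C(F)(F)F)c1`) and is 3-(trifluoromethyl)phenyl in place of 4-chlorophenyl on an amide-type nitrogen. Going by the values given here, no measured compound carries this group, so the closest guide is compound 2 with its 3-chlorophenyl. Read in reverse, the step of a 2.2-fold lower number from compound 2 to compound 3 (0.35 log units; beyond the scatter) suggests that leaving 4-chlorophenyl costs a modest rise in the number, and the step of a 2.3-fold lower number from compound 1 to compound 3 (0.37 log units; beyond the scatter) is of similar size. Among the compounds with values here, compound 3 is the only measured compound with 4-chlorophenyl, which limits this reading.

A modest upward move is therefore expected, estimated as a 1.7-fold higher number from compound 3 to compound 4 (0.22 log units; within the scatter) in this assay with wide uncertainty. For compound 4 the estimated value is 55000 nM with an expected range from 22000 nM to 120000 nM.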

Compound 4, half-maximal inhibitory concentration: 58000 nM
Beside the measured number, compound 4's estimate is 1.1-fold (0.02 log units) below it, within the range that was stated.
By their numbers in this assay, from the lowest: compounds 3, 4, 2 and 1 (each within the scatter of the next, the first and the last beyond it).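

In this assay the three new steps, a 1.8-fold higher number from compound 3 to compound 4 (0.24 log units; within the scatter) and a 1.3-fold lower number from compound 2 to compound 4 (0.11 log units; within the scatter) and a 1.3-fold lower number from compound 1 to compound 4 (0.12 log units; within the scatter), all lie within the scatter, so 3-(trifluoromethyl)phenyl on the amide-type nitrogen cannot be told apart from any of the three aryl groups seen earlier. Going by these compounds alone, this changes the picture left by the earlier compounds, in which 4-chlorophenyl stood modestly clear of both 3-chlorophenyl and 4-methoxyphenyl: compound 4 fills that gap, and the series now reads as a narrow spread of four numbers rather than one aryl group set apart from two others. Nothing measured on these compounds accounts for the spread or for compound 4's place in it.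

The step to compound 4 alters the substituent and its ring position together, so 4-(trifluoromethyl)phenyl would be needed to separate the two changes. Also open, as far as these compounds go, is whether an amine or a carboxylic acid on this aryl ring, or a longer chain between the amide-type nitrogen and the ring, would move the number beyond the scatter.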